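The source may report more compounds than this note shows. Statements on the series, on what has been measured and on what is new or still open speak of the compounds shown alone.

Of the compounds shown here, two have been tested so far in a functional assay on the whole organism with Rattus norvegicus as the target, in the maximal electroshock model; a lower number here means that less compound is needed, a higher number that more compound is needed for the effect. Compound 1 (`Nc1nccn2c(Cc3cccc(F)c3)nnc12`) gives > 25 mg/kg as its result, and this is a limit of the assay and not a number. For the measured compounds named here, compound 2 (`CNc1nccn2c(Cc3cc(F)ccc3F)nnc12`) gives 4 mg/kg as the only actual number. Compound 3 (`Nc1nccn2c(Cc3cc(F)ccc3F)nnc12`) has hydrogen in place of methyl on a nitrogen on an aromatic ring relative to compound 2 (hydrogen in place of methyl on a nitrogen on an aromatic ring). Going by the values given here, no measured pair shows what this change does, so the expectation is anchored on compound 2 with its 4 mg/kg as the starting point. A moderate rise in the dose needed is expected, and a result within the usual scatter would not be surprising. The expected size is a 2.0-fold higher number from compound 2 to compound 3 (0.30 log units; within the scatter) as a working estimate. In this assay the estimate for compound 3 is 8 mg/kg with an expected range from 3 mg/kg to 25 mg/kg for this dose.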

Compound 3, dose for half-maximal effect: 7 mg/kg
The estimate for compound 3 lay 1.1-fold (0.06 log units) above the measured number; the range from low to high includes it.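

In this assay, methylamino to amino gives a 1.8-fold higher number from compound 2 to compound 3 (0.24 log units; within the scatter), so at this nitrogen hydrogen and methyl cannot be told apart in the dose needed. Fluoro in place of hydrogen on an aromatic carbon gives an at least 3.5-fold lower number from compound 1 to compound 3 (0.55 log units; beyond the scatter), the first step in the series that lies beyond the scatter and the first sign that the fluoro pattern on the aromatic ring matters more here than the methyl does. Compound 1 holds a limit of the assay and not a number, so the full size of this step cannot be read: the limit of > 25 mg/kg in this assay, at which 1 of the 3 values shown sits.

As far as these compounds go, whether a longer chain such as ethyl, or an acetyl group, on this nitrogen would hold the dose in the same range remains open. Also open, from the compounds shown here alone, is whether chloro could take the place of the added fluoro.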